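Shortening the Alkyl Chain from Compound 3 to Compound 4

A few compounds are considered here, and "the series" means these few. Any claim that something is new, unique, unknown or untested is made for them only; others in the source may bear on it.

Of the compounds shown here, three sharing one core have been measured in a functional assay on HBL-100 cells (Homo sapiens) for antiproliferative activity, read by sulforhodamine B assay, with a stated time of 48 h; a lower number here means a stronger inhibitor of growth, a higher number a weaker inhibitor of growth. Compound 1 `CCCC(C#CC(=O)OC)O/C=C/C(=O)OC` gives 270 nM. Compound 2 `COC(=O)C#CC(O/C=C/C(=O)OC)C(C)C` gives 450 nM. Compound 3 `CCCCCCCCCCC(C#CC(=O)OC)O/C=C/C(=O)OC` gives 2200 nM, the highest of the three numbers; its steps to both other compounds lie beyond the scatter, so it is the weakest inhibitor of growth among them.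

Compound 4 `CCCCC(C#CC(=O)OC)O/C=C/C(=O)OC` has not yet been measured. It differs from compound 3 in one place: hydrogen in place of hexyl on a saturated chain carbon, five bonds along the chain from an oxygen on an unsaturated carbon and a triple-bonded carbon. The step that bears on this is an 8.1-fold higher number from compound 1 to compound 3 (0.91 log units; beyond the scatter), where heptyl took the place of hydrogen four bonds along the chain. The change from compound 3 to compound 4 runs the opposite way, hexyl to hydrogen, five bonds along the chain. The other known step, a 1.7-fold higher number from compound 1 to compound 2 (0.22 log units; within the scatter), with isopropyl in place of propyl, lies within the scatter, which suggests that the length of the chain, not its branching, sets the number. Compound 4 is therefore expected to give a lower number than compound 3, with an expected step of a 6.3-fold lower number from compound 3 to compound 4 (0.80 log units; beyond the scatter). The estimate for compound 4 in this assay is 350 nM, with a range from 150 nM to 900 nM.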

Compound 4, concentration for 50% growth inhibition: 250 nM
Beside the measured number, compound 4's estimate is 1.4-fold (0.15 log units) above it; measured number inside the range.
By their numbers in this assay, from the lowest: compounds 4, 1 and 2 (each within the scatter of the next); then compound 3.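

In this assay, the change from hexyl to hydrogen at this position gives an 8.8-fold lower number from compound 3 to compound 4 (0.94 log units; beyond the scatter), so the butyl chain of compound 4 does not carry the penalty seen with the much longer chain of compound 3. Among the shorter chains, the extra methyl gives a 1.1-fold lower number from compound 1 to compound 4 (0.03 log units; within the scatter) and butyl in place of isopropyl gives a 1.8-fold lower number from compound 2 to compound 4 (0.26 log units; within the scatter), so the propyl, isopropyl and butyl compounds cannot be told apart, and only compound 3 stands clear of the others. No measurement in hand explains why the long chain gives a higher number or why these shorter chains cannot be separated.

The compounds shown leave open where between butyl and the chain of compound 3 the number begins to climb, which a hexyl or octyl chain at this carbon could help locate, and whether methyl or ethyl would hold the number at the same level. They also leave open whether a chain carrying an amine or a carboxylic acid, or a phenyl ring at this carbon, would give a number like these.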